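This account rests on a few compounds, and the source may have more. Where it says the series, first, only, none or still open, it means among the compounds named here.

Measured so far in an ADME assay on the whole organism (Rattus norvegicus, strain Wistar Han) for pharmacokinetics, at a dose of 0.05 mg/kg by the intravenous route; on this read-out higher numbers stand for fast clearance and lower numbers for slow clearance:

compound 1 `O=C(NC1(c2ccc3c(n2)CCN3C(=O)OC2CC2)CC1)c1ccc(Cl)cc1` gives 4.8 mL/min/kg
compound 2 `O=C(C1CC1)N1CCc2nc(C3(C(=O)Nc4ccc(F)cc4)CCC3)ccc21` gives 60 mL/min/kg

Of these two, compound 2 stands highest, and its gap to compound 1 lies beyond the scatter. Going by the values given here, compound 3 `O=C(OC1CC1)N1CCc2nc(C3(C(=O)Nc4ccc(F)cc4)CCC3)ccc21` differs from compound 2 in one place, with cyclopropyloxy in place of cyclopropyl on a carbonyl carbon and no measured pair shows this change alone. Compound 1 also has cyclopropyloxy on a carbonyl carbon and gives 4.8 mL/min/kg but differs elsewhere too. In this assay the estimated step of a 2.4-fold lower number from compound 2 to compound 3 (0.38 log units; beyond the scatter) is an expected modest fall toward slower clearance. For compound 3 the estimate is 25 mL/min/kg with an expected range of 8 mL/min/kg to 65 mL/min/kg.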

Compound 3, clearance: 61 mL/min/kg
Estimate against measurement, compound 3: 2.4-fold (0.39 log units) below; low and high end bracket the measured number.
By their numbers in this assay, from the lowest: compound 1; then compounds 2 and 3 (each within the scatter of the next).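

In this assay the change from cyclopropyl to cyclopropyloxy, on a carbonyl carbon held by an amide-type nitrogen in a ring, gives a step (a 1.0-fold higher number from compound 2 to compound 3 (0.01 log units; within the scatter)) that leaves compound 2 and compound 3 indistinguishable. This pair reads the change alone, and on this shared core, adding the oxygen does not by itself bring slow clearance. Nothing measured here accounts for this result. Still open, as far as these compounds go, is whether an amine or a longer chain on this carbonyl carbon would move clearance, and whether the same change reads alike on another core.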